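A few compounds are considered here, and "the series" means these few. Any claim that something is new, unique, unknown or untested is made for them only; others in the source may bear on it.

Measured compounds:
compound 2 `CN1CCN(c2ccc(Nc3ncc4nc(Nc5ccc(F)cc5)n([C@H]5CCCN(S(=O)(=O)C6CC6)C5)c4n3)cc2)CC1` gives 1340 nM;
compound 3 `CN1CCN(c2ccc(Nc3ncc4nc(Nc5ccccc5)n([C@H]5CCN(S(=O)(=O)C6CC6)C5)c4n3)cc2)CC1` gives 1670 nM;
compound 1 `CN1CCN(c2ccc(Nc3ncc4nc(Nc5ccccc5)n([C@H]5CCNC5)c4n3)cc2)CC1` gives "not determined" (no result reported), no result being reported for it.

In a functional assay on A-431 cells (Homo sapiens) for antiproliferative activity, read by MTT assay, with a stated time of 72 h (on this read-out lower numbers stand for stronger inhibition and higher numbers for weaker inhibition), compound 2 carries the lowest of the two numbers; its nearest neighbour is compound 3, whose number lies within the scatter of it, so the two are read as equivalent. Within the data shown here, no step between measured compounds differing in a single place is available, so the step to compound 4 `CN1CCN(c2ccc(Nc3ncc4nc(Nc5ccc(F)cc5)n([C@H]5CCCN(C(=O)CO)C5)c4n3)cc2)CC1` rests on the change alone: (hydroxymethyl)carbonyl in place of cyclopropylsulfonyl on an amine nitrogen in a ring. The shared core and the remainder of compound 2 are unchanged. The expectation in this assay is for no step beyond the scatter from compound 2 to compound 4, direction undetermined, so a 1.1-fold higher number from compound 2 to compound 4 (0.05 log units; within the scatter) is estimated. Compound 4 is estimated at 1500 nM, range 600 nM to 4000 nM.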

Compound 4, half-maximal inhibitory concentration: 3000 nM
Compound 4: the middle estimate sits 2.0-fold (0.30 log units) below what was measured; low and high end bracket the measured number.
By their numbers in this assay, from the lowest: compounds 2, 3 and 4 (each within the scatter of the next, the first and the last beyond it).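

In this assay, among these compounds, the exchange of cyclopropylsulfonyl for (hydroxymethyl)carbonyl on the amine nitrogen in a ring gives a 2.2-fold higher number from compound 2 to compound 4 (0.35 log units; beyond the scatter) and is the first readable step at this position. The step is modest, so a measurable antiproliferative number at this position does not depend on the sulfonyl group or the three-membered ring. Nothing available accounts for the size of this step.

An acetyl group or an aminoacetyl group on the same nitrogen would help separate the contribution of the hydroxyl from that of the carbonyl. From the compounds shown here alone, the effect of a longer hydroxyalkyl chain on the carbonyl also remains open.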